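Chalcone-pyrazole series: removing a methoxy from compound 1

A few compounds are considered here, and "the series" means these few. Any claim that something is new, unique, unknown or untested is made for them only; others in the source may bear on it.

Measured compounds:
compound 1 `COc1cc(-c2cc(/C=C/C(=O)c3ccc(N)cc3)[nH]n2)cc(OC)c1OC`, 2770 nM
compound 2 `COc1ccc(-c2cc(/C=C/C(=O)c3ccc(OC)c(OC)c3)[nH]n2)cc1`, 1330 nM
compound 3 `COc1cc(-c2cc(/C=C/C(=O)c3ccc(Cl)c(Cl)c3)[nH]n2)cc(OC)c1OC`, 6730 nM

In a functional assay on RPMI-8226 cells (Homo sapiens) for inhibition, read by sulforhodamine B assay, with a stated time of 48 h (on this read-out lower numbers stand for stronger inhibition of growth and higher numbers for weaker inhibition of growth), compound 1 holds the second highest of the three numbers. Compound 2 gives 1330 nM, and compound 3 gives 6730 nM. Within the data shown here, the one single-point step, a 2.4-fold higher number from compound 1 to compound 3 (0.39 log units; beyond the scatter), changes the 3,4-dichlorophenyl in place of 4-aminophenyl on a carbonyl carbon, a modest step.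

Compound 4 `COc1ccc(-c2cc(/C=C/C(=O)c3ccc(N)cc3)[nH]n2)cc1OC` differs from compound 1 by hydrogen in place of methoxy on an aromatic carbon. Among the measured compounds shown here, no measured pair differs at that place alone, so no step bears directly on this change, and nothing beyond the scatter is expected in this assay. Compound 4 is therefore estimated at 2600 nM (range 900 nM to 7500 nM), which would mean an expected step of a 1.1-fold lower number from compound 1 to compound 4 (0.03 log units; within the scatter).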

Compound 4, concentration for total growth inhibition: 5520 nM
Compound 4: middle estimate off by 2.1-fold (0.33 log units), on the low side; measured number inside the range.
By their numbers in this assay, from the lowest: compound 2; then compounds 1, 4 and 3 (each within the scatter of the next, the first and the last beyond it).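

Hydrogen in place of methoxy on this aromatic carbon gives a 2.0-fold higher number from compound 1 to compound 4 (0.30 log units; within the scatter) in this assay and so stays within the scatter, the first direct reading at this position. The earlier step concerned only the group on the carbonyl carbon, so this methoxy position now has a reading of its own. No measurement at hand offers a cause for this step.

Open, as far as these compounds go, is whether a hydroxy group, an amine or a longer chain such as ethoxy on this carbon would give a step beyond the scatter. Also open, from the compounds shown here alone, is whether the same change reads alike with 3,4-dichlorophenyl on the carbonyl carbon.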